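Swapping chloro for methyl on a pyrazole ester series

The compounds below may be only part of what the source reports. "The series", "measured", "known", "first", "only" and "open" are said of these compounds alone.

Three related compounds have been tested in a functional assay on the whole organism (strain albino) for inhibition, with Rattus norvegicus as the target, read by paw edema, with stated times of 30 min and 24 h, at a dose of 50 mg/kg by the oral route; on this read-out higher numbers stand for more inhibition at the one dose given (going by the name of the read-out) and lower numbers for less inhibition. Compound 1, `O=C(O)CCC(=O)/C=C/c1cn(-c2ccccc2)nc1-c1ccc(Cl)cc1`, gives 2.27%. Compound 2, `NC(=O)c1ccccc1OC(=O)c1cn(-c2ccccc2)nc1-c1ccc(Br)cc1`, gives 3.09%. Compound 3, `CC(=O)Nc1ccc(OC(=O)c2cn(-c3ccccc3)nc2-c2ccc(Cl)cc2)cc1`, gives 3.79%, the highest of the three numbers, though the gaps to compound 2 and compound 1 both lie within the usual scatter, so no ordering can be read from them. Compound 4, `CC(=O)Nc1ccc(OC(=O)c2cn(-c3ccccc3)nc2-c2ccc(C)cc2)cc1`, has not yet been tested. The difference from compound 3 is methyl in place of chloro on an aromatic carbon. Within the data shown here, with all three measured numbers so close together and no measured pair sharing this change, the step in this assay from compound 3 to compound 4 is expected to stay within the scatter, in no particular direction: the estimate is a number 0.3 percentage points lower from compound 3 to compound 4 (within the scatter). Compound 4 is therefore expected to give about 3.5%, between 0% and 9%.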

Compound 4, a percentage reported as inhibition, in the whole organism at one dose (the size of the read-out at that dose, not a potency): 9.09%
Compound 4: the middle estimate sits 5.6 percentage points below what was measured; the whole stated range lies below it.
By their numbers in this assay, from the lowest: compounds 1, 2, 3 and 4 (each within the scatter of the next).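

Among these compounds, the swap of 4-chlorophenyl to 4-methylphenyl gives the first comparison in this set where only one place differs, and in this assay it reads a number 5.3 percentage points higher from compound 3 to compound 4 (within the scatter). So this single change does not separate methyl from chloro at this position on the ring. Nothing available here bears on the reason for this reading. The compounds shown leave open how an amine, a methoxy group or a longer chain such as propyl would read at this position. They also leave open whether the same swap reads alike on a different ester.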